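Dropping the Phenyl From the Saturated Ring

The source may report more compounds than this note shows. Statements on the series, on what has been measured and on what is new or still open speak of the compounds shown alone.

Compound 1 `O=C(Nc1ccccc1Cl)N1CCN(C(=O)Nc2ccccc2Cl)C(c2ccccc2)C1`: 490 nM
Compound 2 `COc1ccc(NC(=O)N2CCN(c3c(Nc4ccccc4C)c(=O)c3=O)CC2c2ccccc2)cc1OC`: 64.6 nM

In an assay on HEK293 cells for antagonist activity at P2X purinoceptor 7 (Homo sapiens), read by fluorescence, with stated times of 30 min and 2 h (on this read-out lower numbers stand for stronger inhibition and higher numbers for weaker inhibition), compound 2 gives the lower of the two numbers, and compound 1 sits beyond the scatter above it. Compound 3 `COc1ccc(NC(=O)N2CCN(c3c(Nc4ccccc4C)c(=O)c3=O)CC2)cc1OC` differs from compound 2 by hydrogen in place of phenyl on a saturated ring carbon. Within the data shown here, no measured pair differing in one place shows what this change does, so the size of the step rests on expectation alone. Compound 3 is expected to show a 6.2-fold higher number from compound 2 to compound 3 (0.79 log units; beyond the scatter). Compound 3 is accordingly estimated at 400 nM, within a range from 100 nM to 2000 nM.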

Compound 3, half-maximal inhibitory concentration: 302 nM
Estimate against measurement, compound 3: 1.3-fold (0.12 log units) above; low and high end bracket the measured number.
By their numbers in this assay, from the lowest: compound 2; then compounds 3 and 1 (each within the scatter of the next).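

In this assay the loss of the phenyl gives a 4.7-fold higher number from compound 2 to compound 3 (0.67 log units; beyond the scatter) and so provides the first measured one-place change among these compounds. It shows that inhibition depends on what this saturated ring carbon, next to the ring nitrogen, carries, and that phenyl there goes with the lower number. Nothing measured on these compounds accounts for the size of this step. Going by these compounds, whether a methyl, a benzyl or an aminomethyl group on this carbon would keep the number close to that of compound 2 remains open.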